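Removing a Methoxy Group and Watching Metabolic Stability

The compounds below may be only part of what the source reports. "The series", "measured", "known", "first", "only" and "open" are said of these compounds alone.

Of the compounds shown here, two that share a core have been measured so far. Compound 1, `CC(=O)Nc1cc(-c2ccc(OC[C@@](C)(N)CC(C)C)c(F)c2)ccn1`, carries an acetamide and a fluorine-bearing ring; in an ADME assay on microsomes from liver (Homo sapiens) for metabolic stability, read by LC-MS, using NADPH, with a stated time of 10 min, tested at 0.5 uM (a higher number here means that more of the compound is left, a lower number that less of the compound is left), compound 1 gives 91%. Compound 2, `COC(=O)Nc1cc(-c2cnc(OC[C@@](C)(N)CC(C)C)c(OC)c2)ccn1`, carries a methyl carbamate instead and a methoxy group on a ring with one nitrogen; in this assay compound 2 gives 86%. Compound 2 has the smaller of the two numbers, yet its gap to compound 1 lies within the usual scatter of this measurement, so on the evidence available the two compounds cannot be told apart, and both keep most of the compound intact.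

Compound 3, `COC(=O)Nc1cc(-c2ccc(OC[C@@](C)(N)CC(C)C)nc2)ccn1`, has not yet been measured. It differs from compound 2 in one place: hydrogen in place of methoxy on an aromatic carbon. Within the data shown here, no measured pair in this small set isolates such a change, so there is no measured step to lean on. With both known values already high, the step from compound 2 to compound 3 is expected to be small, a number 2 percentage points higher from compound 2 to compound 3 (within the scatter), and not clearly beyond the scatter in either direction. Compound 3 is therefore expected to give about 88% in this assay, most likely between 75% and 97%.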

Compound 3, percent of the compound remaining: 100%
Compound 3: middle estimate off by 12 percentage points, on the low side; measured number outside the range, above it.
By their numbers in this assay, from the lowest: compounds 2, 1 and 3 (each within the scatter of the next, the first and the last beyond it).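

On the aromatic carbon ortho to a (2-amino-2,4-dimethylpentyl)oxy group and two atoms from the ring nitrogen, hydrogen in place of methoxy gives in this assay a number 14 percentage points higher from compound 2 to compound 3 (beyond the scatter). Among these compounds, this is the first change in a single place to be measured in this set, and it shows that the group on this carbon can move the read-out, even when compound 2 already keeps most of its starting amount. Nothing measured here explains why the number moves with this change.

The compounds shown leave open how other groups on this same carbon would behave, such as a chlorine atom, an amine or an ethoxy group, whose longer chain would show whether the number falls further as the group grows. On these data alone, it also remains open whether the same swap of methoxy for hydrogen would have a similar effect on the core of compound 1, which differs from compound 3 in more than one place and so cannot be compared with it directly.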